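One More Chain Carbon on the Fluorinated Analogue

The compounds below may be only part of what the source reports. "The series", "measured", "known", "first", "only" and "open" are said of these compounds alone.

Compound 1 `CN(C)C(=O)c1cc2cnc(Nc3ccc(C(=O)NCCCCN=C=S)cc3)nc2n1C1CCCC1` and compound 2 `CN(C)C(=O)c1cc2cnc(Nc3ccc(C(=O)NCCCCCN=C=S)cc3)nc2n1C1CCCC1` differ by a group of 4 heavy atoms (2 carbon, 1 nitrogen, 1 sulfur; no ring) in place of a group of 3 heavy atoms (1 carbon, 1 nitrogen, 1 sulfur; no ring), on a saturated chain carbon, four bonds along the chain from an amide-type nitrogen. In a functional assay on NCI-H1299 cells (Homo sapiens) for inhibition, read by CCK-8 assay, with a stated time of 72 h, tested at 1 uM (on this read-out higher numbers stand for a stronger effect at the one concentration tested and lower numbers for a weaker effect), compound 1 gives 55.2%, while compound 2 gives 50.3%, which is a step of a number 4.9 percentage points lower from compound 1 to compound 2 (within the scatter). Compound 3 `CN(C)C(=O)c1cc2cnc(Nc3ccc(C(=O)NCCCCCCN=C=S)cc3F)nc2n1C1CCCC1` has a different core; the difference between the two cores is not broken down here. In this assay compound 3 gives 29.1%. Compound 4 `CN(C)C(=O)c1cc2cnc(Nc3ccc(C(=O)NCCCCCCCN=C=S)cc3F)nc2n1C1CCCC1` has not yet been measured and differs from compound 3 by a group of 4 heavy atoms (2 carbon, 1 nitrogen, 1 sulfur; no ring) in place of a group of 3 heavy atoms (1 carbon, 1 nitrogen, 1 sulfur; no ring), on a saturated chain carbon, six bonds along the chain from an amide-type nitrogen, the same kind of change as before, though the place is now six bonds along the chain from an amide-type nitrogen rather than four. In this assay the expected step is a number 3.1 percentage points lower from compound 3 to compound 4 (within the scatter). This expectation rests on the earlier step of a number 4.9 percentage points lower from compound 1 to compound 2 (within the scatter). Compound 4 is therefore estimated at 26%, between 12% and 40%.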

Compound 4, a percentage reported as inhibition, at one concentration (the size of the read-out at that concentration, not a potency): -9.23%
For compound 4 the middle estimate is 35.2 percentage points above the measured one; measured number below the stated range.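

In this assay, adding one chain carbon gives a step of a number 38.3 percentage points lower from compound 3 to compound 4 (beyond the scatter). Set beside the earlier step, the same change does not behave alike on the two cores: the same change on two cores in this assay, a number 4.9 percentage points lower (within the scatter) from compound 1 to compound 2 and a number 38.3 percentage points lower (beyond the scatter) from compound 3 to compound 4, 33.4 percentage points apart, beyond the scatter of two such steps

So the size of a step measured on one core cannot simply be carried over to the other in this series, but these two steps alone do not show what sets them apart, as the ring fluorine and the chain length both differ between the starting compounds.

Still open, from the compounds shown here alone, is whether a longer chain would read in this assay like compound 4. Also open, going by these compounds, is how an amine in place of the group ending the chain would read.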